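Working notes: from compound 2 to compound 3

The source may hold more compounds than are shown below. What is called first, only, known or untested is meant among the compounds shown, and "the series" means these compounds.

Going by the values given here, the series so far holds two measured compounds. Compound 1 `CCCCc1ccc(-c2cc(N3CCC(CNS(N)(=O)=O)CC3)ncn2)cc1` gives 47200 nM in a functional assay on M21 cells (Homo sapiens) for antiproliferative activity, read by sulforhodamine B assay, with a stated time of 48 h; a lower number here means a stronger inhibitor of growth, a higher number a weaker inhibitor of growth. Compound 2 `NS(=O)(=O)NCC1CCN(c2cc(-c3ccc(C(F)(F)F)cc3)ncn2)CC1` gives 43100 nM in this assay. Among the compounds with values here, the only step between them, a 1.1-fold lower number from compound 1 to compound 2 (0.04 log units; within the scatter), is the exchange of butyl for trifluoromethyl on an aromatic carbon. On these two numbers compound 2 stands at the lower of the pair, yet within the scatter of compound 1, so no order can be claimed.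

Compound 3 `COC(=O)c1ccc(-c2cc(N3CCC(CNS(N)(=O)=O)CC3)ncn2)cc1` is the next member, not yet measured. It differs from compound 2 as follows: methoxycarbonyl in place of trifluoromethyl on an aromatic carbon. Within the data shown here, no measured step covers a methoxycarbonyl group; the single step in hand, from butyl to trifluoromethyl, moved nothing beyond the scatter. With no evidence of sensitivity at this position, the step of a 1.0-fold higher number from compound 2 to compound 3 (0.02 log units; within the scatter) is expected to stay within the scatter. Compound 3 is therefore estimated at 45000 nM in this assay, with a range from 15000 nM to 135000 nM.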

Compound 3, concentration for 50% growth inhibition: 14100 nM
Compound 3: middle estimate off by 3.2-fold (0.50 log units), on the high side, outside the stated range (below it).
By their numbers in this assay, from the lowest: compound 3; then compounds 2 and 1 (each within the scatter of the next).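

In this assay, going by these compounds alone, the aromatic carbon para to a large group proves responsive to the group it carries: the exchange gives a 3.1-fold lower number from compound 2 to compound 3 (0.49 log units; beyond the scatter) and, against butyl, a 3.3-fold lower number from compound 1 to compound 3 (0.52 log units; beyond the scatter) as the first steps beyond the scatter. Butyl and trifluoromethyl lie within the scatter of each other, so methoxycarbonyl alone stands apart among the three groups, and it brings a double bond outside aromatic rings and hydrogen-bond acceptors that trifluoromethyl lacks. Which of these features, if either, goes with the lower number cannot be told, and nothing at hand bears on the cause.

Going by these compounds, whether the shift belongs to methoxycarbonyl as a whole or to its carbonyl stays open; a carboxylic acid, a primary amide or an acetyl group on the same carbon would bear on this. Also open, on these data alone, is whether the step holds with any other change to the core of compound 3.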